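The source may hold more compounds than are shown below. What is called first, only, known or untested is meant among the compounds shown, and "the series" means these compounds.

Working notes on the series. Compound 1 `CCC(CC)Nc1nc(C)nc2c(-c3ccc(OC)nc3C)c(C)nn12` and compound 2 `CCCCN(C)c1nc(C)nc2c(-c3ccc(OC)nc3C)c(C)nn12` share one core and differ only in the amino group on the aromatic carbon. In an assay on cell membranes for displacement of a labelled ligand from corticotropin-releasing factor receptor 1 (Rattus norvegicus) (on this read-out lower numbers stand for stronger inhibition and higher numbers for weaker inhibition), compound 1 gives 3.1 nM, and compound 2 gives 8.1 nM. Among the compounds with values here, the single measured step, a 2.6-fold higher number from compound 1 to compound 2 (0.42 log units; beyond the scatter), is modest but beyond the scatter, and compound 2 therefore stands with the higher of the two numbers so far, compound 1 the lower.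

Compound 3 `CCCCC(C)Nc1nc(C)nc2c(-c3ccc(OC)nc3C)c(C)nn12` carries (1-methylpentyl)amino in place of butyl(methyl)amino on an aromatic carbon. The incoming group keeps the amine hydrogen that the (pentan-3-yl)amino group of compound 1 has and that the butyl(methyl)amino group of compound 2 lacks, while the chain grows by the count given. Within the data shown here, the only step that bears on this change is a 2.6-fold higher number from compound 1 to compound 2 (0.42 log units; beyond the scatter), read in the reverse direction: removing the methyl from the nitrogen and branching the chain moved the number down. Compound 3 is therefore expected to move back toward compound 1, a step estimated as a 2.3-fold lower number from compound 2 to compound 3 (0.36 log units; beyond the scatter) in this assay. The estimate for compound 3 is 3.5 nM, with a range from 1.5 nM to 8 nM.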

Compound 3, half-maximal inhibitory concentration: 5.1 nM
The estimate for compound 3 lay 1.5-fold (0.16 log units) below the measured number; the measured number falls inside the stated range.
By their numbers in this assay, from the lowest: compounds 1, 3 and 2 (each within the scatter of the next, the first and the last beyond it).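

In this assay, the step of a 1.6-fold lower number from compound 2 to compound 3 (0.20 log units; within the scatter) and the step of a 1.6-fold higher number from compound 1 to compound 3 (0.22 log units; within the scatter) both stay inside the scatter, so compound 3 cannot be separated from either neighbour, even though compound 1 and compound 2 are themselves separated by a 2.6-fold higher number from compound 1 to compound 2 (0.42 log units; beyond the scatter). On this aromatic carbon, 1-methylpentyl in place of pentan-3-yl on the nitrogen is therefore a change the read-out does not resolve, and the same holds for (1-methylpentyl)amino in place of butyl(methyl)amino, although that change brings back the amine hydrogen. The step from compound 1 to compound 2 thus cannot be assigned to the loss of the amine hydrogen alone, and no supporting data bear on the reason for these numbers.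

The compounds shown leave open how an unbranched butylamino group would compare, which would separate the amine hydrogen from the branching of the chain. They also leave open whether a cyclopentylamino group, or a dibutylamino group with two longer chains on the nitrogen, would give a number beyond the scatter of these three.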